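A few compounds are considered here, and "the series" means these few. Any claim that something is new, unique, unknown or untested is made for them only; others in the source may bear on it.

The study concerns a small set of related compounds read in a functional assay on cells (Lymphocyte, Homo sapiens), read by a luciferase reporter and ATP content, with a stated time of 48 h, tested at 5 uM; on this read-out higher numbers stand for a weaker effect at the one concentration tested and lower numbers for a stronger effect. Compound 1 `Cc1nc(OC2CCC2)nc(N2CCC2)c1O` gives 99% in this assay. Compound 2 `CCCCCCCCCCCCCCc1nc(OC2CCC2)nc(N2CCC2)c1O` gives 105% in this assay, and compound 3 `CCCCCCCCCCCCCCc1nc(OC2CCC2)nc(OC2CCC2)c1O` gives 98% in this assay. The difference between the cores of compound 1 and compound 3 is not broken down here. Compound 3 and compound 2 differ in one place: azetidin-1-yl in place of cyclobutyloxy on an aromatic carbon. That step, a number 7 percentage points higher from compound 3 to compound 2 (within the scatter), leaves the read-out essentially where it was.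

Compound 4 `Cc1nc(N2CCC2)nc(N2CCC2)c1O` has not yet been measured in this assay. It differs from compound 1 by the same kind of change: azetidin-1-yl in place of cyclobutyloxy on an aromatic carbon. The surroundings are not the same, however: in compound 2 the entering group sits next to the ring nitrogen, ortho to a hydroxy group, meta to a cyclobutyloxy group, meta to a large group and opposite the ring nitrogen, whereas in compound 4 it sits between two ring nitrogen atoms, meta to a methyl group, meta to an azetidin-1-yl group and para to a hydroxy group. Because the earlier step of a number 7 percentage points higher from compound 3 to compound 2 (within the scatter) stayed within the scatter, and because compound 1 gives 99% close to the other two, the change is expected to make little difference. Compound 4 is expected to give 101% in this assay, within an estimated range from 90% to 112%. The step this estimate means, a number 2 percentage points higher from compound 1 to compound 4 (within the scatter), is expected to stay within the scatter.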

Compound 4, a percentage reported as activity, at one concentration (the size of the read-out at that concentration, not a potency): 101%
Compound 4: the middle estimate sits on the measured number at the digits printed; the range from low to high includes it.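

In this assay, putting azetidin-1-yl in place of cyclobutyloxy on the core of compound 1 gives a number 2 percentage points higher from compound 1 to compound 4 (within the scatter) and so leaves the read-out essentially where it was. Set beside the earlier step on the core of compound 3, the change looks the same on both cores, as far as this read-out can separate them: the same change on two cores in this assay, a number 7 percentage points higher (within the scatter) from compound 3 to compound 2 and a number 2 percentage points higher (within the scatter) from compound 1 to compound 4, 5 percentage points apart, within the scatter of two such steps

This agreement is between two steps that show no measurable effect, so it supports only the narrow statement that, at the one concentration tested, the exchange of cyclobutyloxy for azetidin-1-yl left the read-out unmoved on these two cores; it does not show that the change would carry over unaltered to a core on which the read-out departs from the values seen here, and it says nothing about potency.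

The compounds shown leave open whether any other group in that place, such as a morpholine, a dimethylamino group or a carboxylic acid, would move the read-out on either core. They also leave open what a chain of intermediate length in place of the methyl group, or a methoxy group in place of the hydroxy group, would do in this assay.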